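Returning the Amide From Benzyl to an Aryl Group

The compounds below may be only part of what the source reports. "The series", "measured", "known", "first", "only" and "open" are said of these compounds alone.

Of the compounds shown here, three sharing one core have been measured in a functional assay on Huh-7 cells (Homo sapiens) for inhibition, read by MTT assay, with a stated time of 48 h; on this read-out lower numbers stand for stronger inhibition and higher numbers for weaker inhibition. Compound 1 `COc1ccc2c(=O)c(/C=C/C(=O)Nc3ccc(Cl)cc3)coc2c1` carries a 4-chlorophenyl group on its amide-type nitrogen and gives 37100 nM. Compound 2 `COc1ccc2c(=O)c(/C=C/C(=O)NCc3ccccc3)coc2c1`, with a benzyl group in that place, gives 13600 nM, and compound 3 `COc1ccc2c(=O)c(/C=C/C(=O)NCc3ccc(C)cc3)coc2c1`, with a 4-methylbenzyl group, gives 14300 nM. Compound 3 thus stands second highest of the three numbers: it lies within the scatter of compound 2 (a 1.1-fold higher number from compound 2 to compound 3 (0.02 log units; within the scatter)) and clearly apart from compound 1 (a 2.6-fold lower number from compound 1 to compound 3 (0.41 log units; beyond the scatter)).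

Compound 4 `COc1ccc(NC(=O)/C=C/c2coc3cc(OC)ccc3c2=O)cc1` has not yet been measured. It differs from compound 3 in one place: 4-methoxyphenyl in place of 4-methylbenzyl on an amide-type nitrogen. This puts an aryl group directly on the amide-type nitrogen again, as in compound 1, with 4-methoxyphenyl now in place of the 4-chlorophenyl seen there. For the measured compounds named here, the steps that bear on this are the moves from an aryl to a benzyl amide, a 2.7-fold lower number from compound 1 to compound 2 (0.44 log units; beyond the scatter) and a 2.6-fold lower number from compound 1 to compound 3 (0.41 log units; beyond the scatter), both modest and beyond the scatter. Reversing that direction, compound 4 is expected to show a modest rise in the number, a 2.1-fold higher number from compound 3 to compound 4 (0.32 log units; beyond the scatter). Going by the values given here, no measured pair shows what 4-methoxyphenyl does compared with 4-chlorophenyl, so that part stays open and widens the range. Compound 4 is therefore estimated at 30000 nM, with a range from 12000 nM to 75000 nM.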

Compound 4, half-maximal inhibitory concentration: > 100000 nM
Compound 4 was reported as a limit; the forecaster's own chance of this, stated with the estimate: 10%; at least 3.3-fold (0.52 log units) between middle value and limit.
By their numbers in this assay, from the lowest: compounds 2 and 3 (each within the scatter of the next); then compound 1. At a limit, above all of these: compound 4.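

In this assay compound 4 is reported only as a limit, not as a number: the limit of > 100000 nM in this assay, at which 1 of the 4 values shown sits. Replacing a benzyl-type group on the amide-type nitrogen with 4-methoxyphenyl gives larger steps than the earlier move between aryl and benzyl amides, with an at least 6.9-fold higher number from compound 3 to compound 4 (0.84 log units; beyond the scatter) and an at least 7.3-fold higher number from compound 2 to compound 4 (0.86 log units; beyond the scatter). The group carried on the aryl ring also matters, as methoxy in place of chloro on an aromatic carbon gives an at least 2.6-fold higher number from compound 1 to compound 4 (0.43 log units; beyond the scatter), so having an aryl group on this nitrogen does not by itself fix the level of inhibition.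

The full size of these steps stays open, and the compounds shown give no reason for them. Also open, from the compounds shown here alone, is how a phenethyl group, with a longer chain between the amide-type nitrogen and the ring, or a benzyl group carrying an amine or a carboxylic acid would compare with the plain benzyl group of compound 2.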